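Swapping Chloro for Fluoro on the Aryl Ring

The source may hold more compounds than are shown below. What is called first, only, known or untested is meant among the compounds shown, and "the series" means these compounds.

Measured in a functional assay on A-431 cells (Homo sapiens) for inhibition, read by MTT assay, with a stated time of 72 h; a higher number here means a weaker inhibitor, a lower number a stronger inhibitor:
Compound 1 `O=[N+]([O-])c1ccc(-c2nnc(SCCCN3CCN(c4nc5ccccc5s4)CC3)o2)cc1`: 46500 nM
Compound 2 `Cc1ccc(-c2nnc(SCCCN3CCN(c4nc5ccccc5s4)CC3)o2)cc1`: 61600 nM
Compound 3 `Clc1ccc(-c2nnc(SCCCN3CCN(c4nc5ccccc5s4)CC3)o2)cc1`: 69200 nM

The three compounds share one core and differ only in the group on the aromatic ring. Compound 3 does not separate from the other two: the data show a 1.1-fold higher number from compound 2 to compound 3 (0.05 log units; within the scatter) and a 1.5-fold higher number from compound 1 to compound 3 (0.17 log units; within the scatter). Compound 4 `Fc1ccc(-c2nnc(SCCCN3CCN(c4nc5ccccc5s4)CC3)o2)cc1` has not yet been measured. It takes compound 3 from 4-chlorophenyl to 4-fluorophenyl, with fluoro in place of chloro on an aromatic carbon, para to a large group: fluoro in place of chloro on an aromatic carbon.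

Among the compounds with values here, no measured compound carries fluoro, so the closest evidence is the set of exchanges at this same place. Besides the two steps to compound 3, the data show a 1.3-fold higher number from compound 1 to compound 2 (0.12 log units; within the scatter). All three stay within the scatter, even though nitro, methyl and chloro are exchanged. On that basis, the expected step is a 1.1-fold lower number from compound 3 to compound 4 (0.05 log units; within the scatter), with no change beyond the scatter anticipated. The estimate for compound 4 is 62000 nM, with an expected range of 32000 nM to 115000 nM.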

Compound 4, half-maximal inhibitory concentration: 67000 nM
The estimate for compound 4 lay 1.1-fold (0.03 log units) below the measured number; measured number inside the range.
By their numbers in this assay, from the lowest: compounds 1, 2, 4 and 3 (each within the scatter of the next).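

Fluoro brings a fourth group to the same place on the aromatic ring, and in this assay it does not separate from the other three, with a 1.0-fold lower number from compound 3 to compound 4 (0.01 log units; within the scatter) and a 1.1-fold higher number from compound 2 to compound 4 (0.04 log units; within the scatter) and a 1.4-fold higher number from compound 1 to compound 4 (0.16 log units; within the scatter) all within the scatter. At this position, on an aromatic carbon para to a large group, nitro, methyl, chloro and fluoro therefore cannot be told apart, and exchanging chloro for fluoro gives no step beyond the scatter. The data at hand hold no measurement that would explain this flat result.

The compounds shown leave open whether a group of another kind at this place, such as an amine or a carboxylic acid, would separate from these four. They also leave open what a longer chain in the shared core would do.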